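This account rests on a few compounds, and the source may have more. Where it says the series, first, only, none or still open, it means among the compounds named here.

Measured so far, in a functional assay on DU-145 cells (Homo sapiens) for antiproliferative activity; a higher number here means a weaker inhibitor, a lower number a stronger inhibitor:

- compound 1 `CC(O)(C[S+]([O-])c1ccc(C(F)(F)F)cn1)C(=O)Nc1ccc([N+](=O)[O-])cc1C(F)(F)F`: > 100000 nM; > 100000 nM (2 entries), a limit of the assay, not a number
- compound 2 `CC(O)(C[S+]([O-])c1ccc(C(F)(F)F)cc1)C(=O)Nc1ccc([N+](=O)[O-])cc1C(F)(F)F`: 36500 nM
- compound 3 `CC(O)(C[S+]([O-])c1ccccn1)C(=O)Nc1ccc(C#N)c(C(F)(F)F)c1`: > 100000 nM, a limit of the assay, not a number

Among the compounds with values here, compound 2 is the only member of the set with a single number in this assay; compound 1 gives only a limit, as does compound 3, and the set sits close to the limit of > 100000 nM in this assay, at which 1 of the 3 values shown sits. Compound 2 stands alone with a number, so nothing in the measured data shows how any change on the sulfur-bound aryl group moves this assay.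

Compound 4 `CC(O)(C[S+]([O-])c1ccccc1OC(F)(F)F)C(=O)Nc1ccc([N+](=O)[O-])cc1C(F)(F)F` is unmeasured. It differs from compound 2 by 2-(trifluoromethoxy)phenyl in place of 4-(trifluoromethyl)phenyl on a sulfur. Within the data shown here, no measured step between compounds that differ in one place exists here, so the size of the change is open. Given that compound 2 itself sits near the limit, the step from compound 2 to compound 4 is expected to be small, within the scatter, as a 1.1-fold higher number from compound 2 to compound 4 (0.04 log units; within the scatter). Compound 4 is therefore estimated at 40000 nM in this assay, between 12000 nM and 150000 nM, with a fair chance that only a limit is returned.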

Compound 4, half-maximal inhibitory concentration: 31100 nM
Compound 4: middle estimate off by 1.3-fold (0.11 log units), on the high side; the range from low to high includes it.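

In this assay, the aryl group on the sulfur now has its first readable step: 2-(trifluoromethoxy)phenyl in place of 4-(trifluoromethyl)phenyl gives a 1.2-fold lower number from compound 2 to compound 4 (0.07 log units; within the scatter). This place in the series therefore accepts a change of substituent and its site on the ring, with an added oxygen, without a shift beyond the scatter, so compound 2 and compound 4 read as equal here. The step shows no gain in inhibition, and the set stays close to the ceiling of the assay: the limit of > 100000 nM in this assay, at which 1 of the 4 values shown sits.

Steps to compound 1 and compound 3, which give only limits, cannot be read. Open, as far as these compounds go, is whether an amine or a carboxylic acid on this aryl group, or a longer chain in its place, would move the number beyond the scatter.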